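The source may hold more compounds than are shown below. What is called first, only, known or untested is meant among the compounds shown, and "the series" means these compounds.

In a functional assay on the whole organism for inhibition, with Mythimna separata as the target, with a stated time of 5 days (a higher number here means that more compound is needed for the effect, a lower number that less compound is needed), compound 1 `CC(C)(C)n1ncc(OCc2nnc(-c3ccc(Cl)cc3)o2)c(Cl)c1=O` gives 1.9 ug/mL, the lowest of the two numbers in hand. Compound 2 `CC(C)(C)n1ncc(OCc2nnc(-c3ccc(C(F)(F)F)cc3)o2)c(Cl)c1=O` gives 34.1 ug/mL in this assay. For the measured compounds named here, the one step measured so far, an 18-fold higher number from compound 1 to compound 2 (1.25 log units; beyond the scatter), is large and concerns the same 4-chlorophenyl group. Compound 3 `Cc1cccc(-c2nnc(COc3cnn(C(C)(C)C)c(=O)c3Cl)o2)c1` carries 3-methylphenyl in place of 4-chlorophenyl on an aromatic carbon. Going by the values given here, no measured step covers this exact change; an upward move in this assay is expected because an 18-fold higher number from compound 1 to compound 2 (1.25 log units; beyond the scatter) shows that altering the 4-chlorophenyl group shifts the number strongly. For compound 3 the estimate is 8 ug/mL, with a range of 2 ug/mL to 40 ug/mL. The expected step is a 4.2-fold higher number from compound 1 to compound 3 (0.62 log units; beyond the scatter).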

Compound 3, half-maximal effective concentration: 116 ug/mL
Compound 3: middle estimate off by 15-fold (1.16 log units), on the low side, and the stated range ends below it.
By their numbers in this assay, from the lowest: compound 1; then compound 2; then compound 3.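

In this assay the change to 3-methylphenyl gives a 61-fold higher number from compound 1 to compound 3 (1.79 log units; beyond the scatter), and compound 3 has the highest number of the three. The heavy-atom count and the carbon-only aromatic ring stay the same in this swap, so neither count separates compound 1 from compound 3. No measurement here accounts for this rise.

For the compounds shown here, the single swap alters both the substituent and where it sits on the phenyl ring, and the two effects cannot be separated. From the compounds shown here alone, how an unsubstituted phenyl or a methoxy-bearing phenyl would behave at this position stays open.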